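From Dichlorophenyl to Fluorophenyl on the Ring Nitrogen

A few compounds are considered here, and "the series" means these few. Any claim that something is new, unique, unknown or untested is made for them only; others in the source may bear on it.

Of the compounds shown here, three have been tested in a functional assay on A549 cells (Homo sapiens) for antiproliferative activity, read by MTT assay, with a stated time of 72 h; a lower number here means a stronger inhibitor, a higher number a weaker inhibitor. Compound 1 `COc1cc(-n2ncnc2-c2ccc(OC(C)C)cc2)cc(OC)c1OC` reaches only the limit of the assay, giving > 10000 nM in this assay. Compound 3 `COc1cc(-n2ncnc2-c2ccc(SC)cc2)cc(OC)c1OC` gives 800 nM in this assay. Going by the values given here, the single measured step, an at least 12-fold lower number from compound 1 to compound 3 (1.09 log units; beyond the scatter), is the only guide to how a change on the outer phenyl ring shifts the read-out. Compound 2 `COc1cc(-c2ncnn2-c2ccc(Cl)c(Cl)c2)cc(OC)c1OC` also stands at the limit in this assay, with > 10000 nM, one of two such values (the limit of > 10000 nM in this assay, at which 2 of the 3 values shown sit). Compound 4 `COc1cc(-c2ncnn2-c2cccc(F)c2)cc(OC)c1OC` differs from compound 2 in one place: 3-fluorophenyl in place of 3,4-dichlorophenyl on an aromatic nitrogen. Among the compounds with values here, no measured step involves a change on the ring nitrogen, and the step from compound 1 to compound 3 concerns a group on an aromatic carbon, so it bears only loosely here. Because compound 2 gives only a limit, no size can be read for the coming step. Compound 4 is therefore expected to remain weak, near 9000 nM, within a range from 2000 nM to 40000 nM. The expected step is an at least 1.1-fold lower number from compound 2 to compound 4 (0.04 log units; that floor lies within the scatter), an estimate rather than a measurement.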

Compound 4, half-maximal inhibitory concentration: > 10000 nM
Compound 4: only a limit was reported; the forecaster's own chance of this, stated with the estimate: 60%; middle value at least 1.1-fold (0.04 log units) from the limit.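

Compound 2 and compound 4 both stop at a limit in this assay, and no step can be read between them: the limit of > 10000 nM in this assay, at which 3 of the 4 values shown sit.

The compounds shown leave open whether exchanging 3,4-dichlorophenyl for 3-fluorophenyl on the aromatic nitrogen changes the antiproliferative read-out at all.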